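Triazole nitrogen substituent: benzyl replacing 3-bromophenyl

The source may report more compounds than this note shows. Statements on the series, on what has been measured and on what is new or still open speak of the compounds shown alone.

The series shares the core of compound 1 `CC(C)n1ncc2c(C(=O)NCc3ccccc3)cccc21`, an amide bearing either a plain benzyl or a triazolylmethyl group. In a functional assay on MGC-803 cells (Homo sapiens) for inhibition, read by MTT assay, with a stated time of 72 h (a lower number here means a stronger inhibitor, a higher number a weaker inhibitor), compound 1 gives only the limit > 40000 nM and no number. Compound 2 `CC(C)n1ncc2c(C(=O)NCc3cn(-c4cccc(Br)c4)nn3)cccc21` carries a 3-bromophenyl on a triazole nitrogen; in this assay compound 2 likewise reaches only the limit > 40000 nM. Compound 3 `Cc1ccc(-n2cc(CNC(=O)c3cccc4c3cnn4C(C)C)nn2)cc1`, with 4-methylphenyl in that place, also stops at the limit > 40000 nM in this assay. The step that the two limits leave unreadable from compound 2 to compound 3 therefore cannot be read, and the limit of > 40000 nM in this assay, at which 3 of the 3 values shown sit, is all the evidence available: every value sits at the same limit.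

Compound 4 `CC(C)n1ncc2c(C(=O)NCc3cn(Cc4ccccc4)nn3)cccc21` differs from compound 2 in one place: benzyl in place of 3-bromophenyl on an aromatic nitrogen. Among the compounds with values here, no measured step informs this change, since the only comparable step, from compound 2 to compound 3, is unreadable between two limits. The expectation for compound 4 is that its value in this assay again lies at or beyond the limit, with the step that the limit leaves unreadable from compound 2 to compound 4 expected to be not readable beyond the scatter. Compound 4 is estimated at 50000 nM, within 20000 nM to 150000 nM, most likely reported only as a limit.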

Compound 4, half-maximal inhibitory concentration: 14300 nM
Beside the measured number, compound 4's estimate is 3.5-fold (0.54 log units) above it, outside the stated range (below it).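

In this assay compound 4 gives a measurable value of 14300 nM, showing that the read-out can respond to the group on this triazole nitrogen. The change gives an at least 2.7-fold lower number from compound 2 to compound 4 (0.44 log units; beyond the scatter) and an at least 2.7-fold lower number from compound 3 to compound 4 (0.44 log units; beyond the scatter), each starting from a value that is only a limit. Benzyl and 3-bromophenyl both count 7 heavy atoms and one six-membered aromatic ring of carbon only, so the gain comes without a change in either count, and compound 4 remains the only compound shown with a number: the limit of > 40000 nM in this assay, at which 3 of the 4 values shown sit.

The step from compound 2 to compound 3 cannot be read, so the compounds shown do not tell 3-bromophenyl and 4-methylphenyl apart. Also open, going by these compounds, are whether the gain belongs to the benzyl ring itself or to the single carbon that joins it to the triazole nitrogen, and how a longer chain such as phenethyl, a substituted benzyl such as 4-fluorobenzyl, or an amine such as dimethylaminoethyl would read at this position.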